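The source may report more compounds than this note shows. Statements on the series, on what has been measured and on what is new or still open speak of the compounds shown alone.

Compound 1 `Clc1cccc(-c2ccc(-c3ccc(-c4nc5ccccc5[nH]4)cc3)cc2)c1`: 41200 nM
Compound 2 `Oc1cccc2[nH]c(-c3ccc(-c4ccc(-c5ccc(C(F)(F)F)cc5)cc4)cc3)nc12`: 5110 nM
Compound 3 `Oc1cccc2[nH]c(-c3ccc(-c4ccc(-c5ccc(OC(F)(F)F)cc5)cc4)cc3)nc12`: 3800 nM

In a functional assay on ZR-75-1 cells (Homo sapiens) for inhibition, read by sulforhodamine B assay (a lower number here means a stronger inhibitor of growth, a higher number a weaker inhibitor of growth), compound 3 gives 3800 nM, which is level with compound 2 once the usual scatter is allowed for. Compound 1 stands clearly higher at 41200 nM, so it is the weaker growth inhibitor of the set.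

The next molecule, compound 4 `Oc1cccc2[nH]c(-c3ccc(-c4ccc(-c5cccc(Cl)c5)cc4)cc3)nc12`, keeps the core of compound 3 but has 3-chlorophenyl in place of 4-(trifluoromethoxy)phenyl on an aromatic carbon.

Two pieces of evidence bear on this change. For the measured compounds named here, the only measured step at this end of the molecule, a 1.3-fold lower number from compound 2 to compound 3 (0.13 log units; within the scatter), stays within the scatter, but it is a smaller swap than the one made here. Going by the values given here, compound 1, at 41200 nM, carries the same 3-chlorophenyl group as compound 4, but its core differs, and no measured pair separates the effect of the core from that of the end group. A modest rise in the number therefore seems more likely than a fall, and the rise may not clear the scatter.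

The expected change is a 1.6-fold higher number from compound 3 to compound 4 (0.20 log units; within the scatter). For compound 4 the estimated value is 6000 nM, with an expected range from 2500 nM to 20000 nM.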

Compound 4, concentration for 50% growth inhibition: 2410 nM
Estimate against measurement, compound 4: 2.5-fold (0.40 log units) above; measured number outside the range, below it.
By their numbers in this assay, from the lowest: compounds 4, 3 and 2 (each within the scatter of the next, the first and the last beyond it); then compound 1.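

In this assay, the change of end ring gives a 1.6-fold lower number from compound 3 to compound 4 (0.20 log units; within the scatter) and a 2.1-fold lower number from compound 2 to compound 4 (0.33 log units; beyond the scatter), so the first step stays level while the second is only a modest drop. At this position, then, 3-chlorophenyl does at least as well as the two fluorinated end groups, and swapping among these three groups moves the number little. For the compounds shown here, the third step, a 17-fold lower number from compound 1 to compound 4 (1.23 log units; beyond the scatter), is far larger and is the first comparison with the end group held fixed: adding a hydroxy to the core of compound 1 accounts for the whole difference between these two compounds. No measurement shown here explains why either kind of change has the size it has.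

From the compounds shown here alone, the effect of the hydroxy has been read only with 3-chlorophenyl at the end, so its size with other end groups remains unknown. Going by these compounds, it is also open whether an end ring carrying an amine or a carboxylic acid, or a methoxy in place of the hydroxy on the core, would keep the number this low.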